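This account rests on a few compounds, and the source may have more. Where it says the series, first, only, none or still open, it means among the compounds named here.

In a physicochemical assay for lipophilicity, measured as octanol-water partition (a lower number here means a more polar compound, a higher number a more lipophilic compound), compound 1 `CCCOc1c(Cl)cc(N/C=N/OCC)cc1Cl` gives 4.6. Compound 2 `C#CCc1c(Cl)cc(N/C=N/OCCC)cc1Cl` gives 4, and compound 3 `C#CCc1c(Cl)cc(N/C=N/OC(C)CC)cc1Cl` gives 4.2, the second highest of the three values: compound 2 is the nearest, within the scatter, while compound 1 lies beyond the scatter above it. Compound 4 `C#CCc1c(Cl)cc(N/C=N/OC/C=C/Cl)cc1Cl` has not yet been measured. From compound 3 to compound 4 the change is 3-chloroprop-2-en-1-yl in place of sec-butyl on an oxygen, one chain swapped for another on the same oxygen. Going by the values given here, the only measured step on that oxygen-bound chain is a number 0.20 log units higher from compound 2 to compound 3 (within the scatter). Among the compounds with values here, no measured pair trades a chain carbon for chlorine or adds a double bond there. Compound 4 is expected to show a step of no change at the digits printed from compound 3 to compound 4 (within the scatter), nothing beyond the scatter. Compound 4 is thus estimated at 4.2, between 3.8 and 4.6.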

Compound 4, partition coefficient: 3.9
Compound 4: the middle estimate sits 0.30 log units above what was measured, and the stated range covers the measured number.
By their numbers in this assay, from the lowest: compounds 4, 2 and 3 (each within the scatter of the next); then compound 1.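

On the oxygen whose other neighbour is a double-bonded nitrogen, a chain holding chlorine and a double bond can stand in for a saturated one: in this assay, 3-chloroprop-2-en-1-yl in place of sec-butyl gives a number 0.30 log units lower from compound 3 to compound 4 (within the scatter). Likewise, 2-chloroethenyl in place of ethyl on the saturated chain carbon gives a number 0.10 log units lower from compound 2 to compound 4 (within the scatter). No measurement at hand offers a cause for these results. Open, as far as these compounds go, is whether an amine or a carboxylic acid on this chain would give a step beyond the scatter, and whether 3-chloroprop-2-en-1-yl gives similar steps on the core of compound 1.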